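A few compounds are considered here, and "the series" means these few. Any claim that something is new, unique, unknown or untested is made for them only; others in the source may bear on it.

Within the data shown here, in a functional assay on the whole organism (strain Wistar) for inhibition, with Rattus norvegicus as the target, read by paw edema, with stated times of 60 min and 1 h, at a dose of 100 mg/kg by the oral route (on this read-out lower numbers stand for less inhibition and higher numbers for more inhibition at the one dose given (going by the name of the read-out)), compound 1 `CCN(CC)C(=O)CC1CCc2cc(OC)c(OC)cc21` gives 31.3%, while compound 2 `COc1cc2c(cc1OC)C(CC(=O)N1CCCCC1)CC2` gives 18.8%, the lower of the two numbers so far. Among the measured compounds shown here, the only measured step, a number 12.5 percentage points lower from compound 1 to compound 2 (beyond the scatter), exchanged the group on the carbonyl carbon, and it was modest though beyond the scatter. For the measured compounds named here, compound 3 `COc1cc2c(cc1OC)C(CC(=O)NCCO)CC2` differs from compound 2 by (2-hydroxyethyl)amino in place of piperidin-1-yl on a carbonyl carbon, a change at that same carbonyl carbon, so this single step is the only guide and suggests a shift of similar size in either direction. Compound 3 is therefore expected to give 25%, in a range from 8% to 42%, an estimated step of a number 6.2 percentage points higher from compound 2 to compound 3 (within the scatter) that may well remain within the scatter.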

Compound 3, a percentage reported as inhibition, in the whole organism at one dose (the size of the read-out at that dose, not a potency): 0%
Compound 3: the middle estimate sits 25 percentage points above what was measured; the whole stated range lies above it.
By their numbers in this assay, from the lowest: compound 3; then compound 2; then compound 1.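

The group on this carbonyl carbon can do more than trim the read-out: in this assay there is a number 18.8 percentage points lower from compound 2 to compound 3 (beyond the scatter) and a number 31.3 percentage points lower from compound 1 to compound 3 (beyond the scatter) with (2-hydroxyethyl)amino in place. The two earlier groups, diethylamino and piperidin-1-yl, both left measurable inhibition, whereas compound 3 gives 0% at the same dose. Nothing measured here explains this loss. As far as these compounds go, it remains open whether the hydroxyl or the amide hydrogen goes with the loss. An ethylamino group, which keeps the amide hydrogen without the hydroxyl, would help separate the two.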